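Aryl replacement on the shared core of compound 3

The source may report more compounds than this note shows. Statements on the series, on what has been measured and on what is new or still open speak of the compounds shown alone.

Measured in a functional assay on CHO-K1 cells for antagonist activity at adenosine receptor A1 (Homo sapiens), read by a beta-galactosidase reporter and cAMP accumulation, with stated times of 15 min and 6 h (a lower number here means a stronger inhibitor, a higher number a weaker inhibitor), so far:
compound 1, `Nc1nc(-c2ncco2)nc2sc(Cc3ccccc3)cc12`, gives 310 nM
compound 2, `Cc1nc(-c2nc(N)c3cc(Cc4ccccc4)sc3n2)cs1`, gives 263 nM
compound 3, `Cn1cnc(-c2nc(N)c3cc(Cc4ccccc4)sc3n2)c1`, gives 2330 nM

Compound 3 stands highest of the three numbers in this assay: the step of a 7.5-fold higher number from compound 1 to compound 3 (0.88 log units; beyond the scatter) and the step of an 8.9-fold higher number from compound 2 to compound 3 (0.95 log units; beyond the scatter) both lie beyond the scatter, while the step of a 1.2-fold lower number from compound 1 to compound 2 (0.07 log units; within the scatter) lies within it. The group on the aromatic carbon between two ring nitrogen atoms is thus the one place where the series has moved.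

Compound 4, `Nc1nc(-c2cccc(F)c2)nc2sc(Cc3ccccc3)cc12`, differs from compound 3 by 3-fluorophenyl in place of 1-methyl-1H-imidazol-4-yl on an aromatic carbon. Among the measured compounds shown here, no measured pair carries a phenyl ring at this position, so no step bears on it directly; the two steps that change this group show the position tolerates replacement with changes of the size seen from compound 1 and compound 2 to compound 3. A return toward the numbers of compound 1 and compound 2 is expected rather than a further rise, and the step of a 5.2-fold lower number from compound 3 to compound 4 (0.71 log units; beyond the scatter) is therefore expected downward. Compound 4 is estimated at 450 nM in this assay, within a range of 100 nM to 2000 nM.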

Compound 4, inhibition constant: 123 nM
Compound 4: the middle estimate sits 3.7-fold (0.56 log units) above what was measured, within the range that was stated.
By their numbers in this assay, from the lowest: compound 4; then compounds 2 and 1 (each within the scatter of the next); then compound 3.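

In this assay, among the compounds shown here, the position accepts a six-membered aromatic ring of carbon only, with no hydrogen-bond acceptors, and the change gives a 19-fold lower number from compound 3 to compound 4 (1.28 log units; beyond the scatter) as the largest step so far. The same group also goes past the two five-membered rings that gave the lower earlier numbers, with a 2.1-fold lower number from compound 2 to compound 4 (0.33 log units; beyond the scatter) and a 2.5-fold lower number from compound 1 to compound 4 (0.40 log units; beyond the scatter) as modest steps beyond the scatter, which makes compound 4 the strongest inhibitor of the four and shows that no ring hetero atom is needed at this position. No data on hand explain any of these steps.

As far as these compounds go, whether the fluorine has any part in these steps stays open, and an unsubstituted phenyl would separate it from the ring itself. From the compounds shown here alone, how a methoxy group or an amine on the phenyl ring would read in this assay is also open.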